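A few compounds are considered here, and "the series" means these few. Any claim that something is new, unique, unknown or untested is made for them only; others in the source may bear on it.

Measured compounds:
compound 1 `CN(C(=O)NC(=O)c1ccc(F)c(F)c1)c1nc(C(F)(F)F)c(C(=O)N/N=C/c2ccc(C(F)(F)F)cc2)s1` — 5.1 ug/mL
compound 2 `CN(C(=O)NC(=O)c1ccc(Cl)cc1Cl)c1nc(C(F)(F)F)c(C(=O)N/N=C/c2ccc(C(F)(F)F)cc2)s1` — 7.99 ug/mL

In a functional assay on HeLa cells (Homo sapiens) for inhibition, read by MTT assay, with a stated time of 72 h (a lower number here means a stronger inhibitor, a higher number a weaker inhibitor), compound 2 and compound 1 lie within the scatter of each other, as a 1.6-fold higher number from compound 1 to compound 2 (0.19 log units; within the scatter) shows; that step swaps one substituted phenyl for another on the carbonyl carbon. Compound 3 `CN(C(=O)NC(=O)c1cccc(C(F)(F)F)c1)c1nc(C(F)(F)F)c(C(=O)N/N=C/c2ccc(C(F)(F)F)cc2)s1` makes a change of the same kind at the same place: 3-(trifluoromethyl)phenyl in place of 2,4-dichlorophenyl on a carbonyl carbon. Going by the values given here, the one step that bears on it was within the scatter, so no step beyond the scatter is expected here either, an estimated 1.2-fold lower number from compound 2 to compound 3 (0.09 log units; within the scatter). Compound 3 is therefore expected to give about 6.5 ug/mL, with a range from 3 ug/mL to 14 ug/mL.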

Compound 3, half-maximal inhibitory concentration: 7.35 ug/mL
For compound 3 the middle estimate is 1.1-fold (0.05 log units) below the measured one, within the range that was stated.
By their numbers in this assay, from the lowest: compounds 1, 3 and 2 (each within the scatter of the next).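

In this assay, a third substitution pattern on the phenyl attached to this carbonyl carbon gives no step beyond the scatter. Exchanging 2,4-dichlorophenyl for 3-(trifluoromethyl)phenyl gives a 1.1-fold lower number from compound 2 to compound 3 (0.04 log units; within the scatter), and exchanging 3,4-difluorophenyl for it gives a 1.4-fold higher number from compound 1 to compound 3 (0.16 log units; within the scatter). No supporting measurement is available to explain this result.

Going by these compounds, it remains open whether the number would stay within the scatter if the phenyl carried an amine or a carboxylic acid. The same question applies if a butyl chain replaced the phenyl entirely.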